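This account rests on a few compounds, and the source may have more. Where it says the series, first, only, none or still open, it means among the compounds named here.

Measured so far in a functional assay on CNE-2 cells (Homo sapiens) for antiproliferative activity, read by sulforhodamine B assay, with a stated time of 48 h; on this read-out lower numbers stand for stronger inhibition and higher numbers for weaker inhibition:
compound 1 `COc1ccc(/C=C/C(=O)c2ccccc2-c2ccc(F)cc2)cc1OC` gives 81 nM;
compound 2 `COc1ccc(/C=C/C(=O)c2ccccc2-c2ccc(F)nc2)cc1OC` gives 1600 nM;
compound 3 `COc1cc(C(=O)/C=C/c2ccccc2-c2ccc(F)cc2)ccc1O` gives 4800 nM.

Compound 1 and compound 2 share one core and differ only by 6-fluoropyridin-3-yl in place of 4-fluorophenyl on an aromatic carbon. That change produced a 20-fold higher number from compound 1 to compound 2 (1.30 log units; beyond the scatter). Compound 4 `COc1cc(C(=O)/C=C/c2ccccc2-c2ccc(F)nc2)ccc1O` has not yet been measured; it differs from compound 3 by 6-fluoropyridin-3-yl in place of 4-fluorophenyl on an aromatic carbon, the same change at the same kind of place. The difference between the core of compound 1 and the core of compound 3 is not broken down here; compound 3 simply gives the highest number of the three. Compound 4 is expected to show a step of about an 8.3-fold higher number from compound 3 to compound 4 (0.92 log units; beyond the scatter) in this assay, resting on a 20-fold higher number from compound 1 to compound 2 (1.30 log units; beyond the scatter), with wide uncertainty since the core is different and the starting point is already weak. Compound 4 is thus estimated at 40000 nM, within 10000 nM to 150000 nM.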

Compound 4, half-maximal inhibitory concentration: 19000 nM
Estimate against measurement, compound 4: 2.1-fold (0.32 log units) above; the measured number falls inside the stated range.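

In this assay the swap of 4-fluorophenyl for 6-fluoropyridin-3-yl again weakens inhibition, giving a 4.0-fold higher number from compound 3 to compound 4 (0.60 log units; beyond the scatter). So the direction of the change carries over between the two cores, but its size does not: the same change on two cores in this assay, a 20-fold higher number (1.30 log units; beyond the scatter) from compound 1 to compound 2 and a 4.0-fold higher number (0.60 log units; beyond the scatter) from compound 3 to compound 4, 5.0-fold (0.70 log units) apart, beyond the scatter of two such steps. For the compounds shown here, with only two cores, this sets no rule for other cores, and it does not show which part of the cores governs the size of the step.

Still open, on these data alone, is how either core would respond if the fluorine on the ring were replaced by an amine or a carboxylic acid. The compounds shown also leave open whether a longer chain at this place would follow the same direction.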